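Cyclohexyl for dichlorophenyl on the benzylic nitrogen substituent

The compounds below may be only part of what the source reports. "The series", "measured", "known", "first", "only" and "open" are said of these compounds alone.

Measured compounds:
Compound 1 `COc1cc2c(=O)c(C(=O)c3ccc(C)cc3)cn(Cc3ccc(Cl)cc3)c2cc1OC`, 15500 nM
Compound 2 `O=C(OCc1ccc(Cl)cc1)c1cn(Cc2ccc(Cl)cc2)c2cc(N3CCNCC3)c(F)cc2c1=O`, 1100 nM
Compound 3 `COc1cc2c(=O)c(C(=O)c3ccc(C)cc3)cn(Cc3ccc(Cl)c(Cl)c3)c2cc1OC`, "not active" (no number reported)

In an ADME assay on Huh-7 cells (Homo sapiens) for cytotoxicity (a lower number here means a stronger inhibitor of growth, a higher number a weaker inhibitor of growth), compound 1 gives 15500 nM, a weak inhibitor of growth. Compound 2, built on a different scaffold, gives 1100 nM in this assay. Compound 3 is reported as "not active" (no number reported) in this assay, so no single number stands for it; it is only known that it showed no measurable inhibition of growth. Compound 3 therefore stands at the weak end of what has been measured, beyond the weakest numbered value, that of compound 1.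

Compound 4 `COc1cc2c(=O)c(C(=O)c3ccc(C)cc3)cn(CC3CCCCC3)c2cc1OC` follows from compound 3 by one change: cyclohexyl in place of 3,4-dichlorophenyl on a saturated chain carbon bound to an aromatic nitrogen. Compound 3 has no number. Among the compounds with values here, no step can be computed. Within the data shown here, on the shared scaffold the only numbered value is the weak one of compound 1, and compound 3 lies weaker still. Compound 4 is therefore expected to remain a weak inhibitor of growth, with a fair chance that this assay again reports only a limit. Compound 4 is estimated at 25000 nM, within a range from 6000 nM to 100000 nM.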

Compound 4, concentration for 50% growth inhibition: 22000 nM
Beside the measured number, compound 4's estimate is 1.1-fold (0.06 log units) above it, within the range that was stated.
By their numbers in this assay, from the lowest: compound 2; then compounds 1 and 4 (each within the scatter of the next).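

In this assay, exchanging 4-chlorophenyl for cyclohexyl on a saturated chain carbon bound to an aromatic nitrogen gives a 1.4-fold higher number from compound 1 to compound 4 (0.15 log units; within the scatter), so on this core an aromatic ring at this place is not needed for a value of this size, and a non-aromatic ring of carbon only serves equally well within the scatter. The step from compound 3 to compound 4, the exchange of 3,4-dichlorobenzyl for cyclohexylmethyl, cannot be read, since compound 3 is reported as not active and has no number to set against the value of compound 4. Nothing shown here gives a reason why these two rings read alike at this place.

Still open, from the compounds shown here alone, is whether an amine or a carboxylic acid on the ring at this place, or a longer chain in place of cyclohexylmethyl, would move the number beyond the scatter on this core. Going by these compounds, it is also open whether cyclohexylmethyl would keep the lower number of compound 2 on the core of that compound, which differs from compound 4 in more than one place.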